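A few compounds are considered here, and "the series" means these few. Any claim that something is new, unique, unknown or untested is made for them only; others in the source may bear on it.

Series notes: esters of a shared core. Compound 1 `CCCOC(=O)c1ccc(CN)cc1` gives 500000000 nM in an assay on isolated protein for inhibition of serine protease 1 (Homo sapiens); a higher number here means a weaker inhibitor, a lower number a stronger inhibitor; compound 2 `CCCCOC(=O)c1ccc(CN)cc1` gives 910000000 nM in this assay. Going by the values given here, the one step measured so far, a 1.8-fold higher number from compound 1 to compound 2 (0.26 log units; within the scatter), keeps the pair together, so compound 2 stands beside compound 1 with no separation beyond the scatter. Compound 3 `CCCCCCOC(=O)c1ccc(CN)cc1` differs from compound 2 by ethyl in place of hydrogen on a saturated chain carbon, four bonds along the chain from an oxygen next to a carbonyl group. Among the compounds with values here, the chain extension between compound 1 and compound 2 is the only step that bears on this change, and it was small. A similar, slight rise in this assay is therefore expected, a 1.5-fold higher number from compound 2 to compound 3 (0.19 log units; within the scatter). Compound 3 is estimated at 1400000000 nM, range 400000000 nM to 5000000000 nM.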

Compound 3, inhibition constant: 300000000 nM
The estimate for compound 3 lay 4.7-fold (0.67 log units) above the measured number; measured number below the stated range.
By their numbers in this assay, from the lowest: compounds 3, 1 and 2 (each within the scatter of the next, the first and the last beyond it).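

Lengthening the chain at this carbon does not keep moving the number the same way: ethyl in place of hydrogen gives a 3.0-fold lower number from compound 2 to compound 3 (0.48 log units; beyond the scatter) in this assay and is the first step in the series beyond the scatter. Propyl in place of hydrogen gives a 1.7-fold lower number from compound 1 to compound 3 (0.22 log units; within the scatter) and so leaves compound 3 within the scatter of compound 1, which makes the chain-length trend non-monotonic across these three esters. Nothing measured here accounts for this reversal.

Open, going by these compounds, is whether a longer chain such as octyl would take the number lower still or back up. Also open, on these data alone, is how a branched chain, or a chain ending in an amine or a carboxylic acid, would behave at this carbon.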